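The source may hold more compounds than are shown below. What is called first, only, known or untested is meant among the compounds shown, and "the series" means these compounds.

Measured in a functional assay on KB cells (Homo sapiens) for cytotoxicity, read by MTT assay, with a stated time of 4 h; on this read-out lower numbers stand for an effect already at smaller amounts and higher numbers for an effect only at larger amounts of compound:
Compound 1 `C[C@@H]1C(CO)=C[C@@]2(C)CC[C@@H]3[C@@H](C)CC[C@@]132`: > 10 ug/mL
Compound 2 `CC(=O)O[C@H]1C[C@H](C)[C@H]2CC[C@]3(C)C=C(C(=O)O)[C@@H](C)[C@]123`: > 10 ug/mL
Compound 3 `COC(=O)C1=C[C@@]2(C)CC[C@@H]3[C@@H](C)C[C@H](OC(C)=O)[C@@]32[C@@H]1C`: > 10 ug/mL

None of these entries is an exact number: the limit of > 10 ug/mL in this assay, at which 3 of the 3 values shown sit. Compound 2 gives > 10 ug/mL, which is a limit of the assay, so it has no exact place on the scale and cannot be ranked against the other two compounds.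

The next compound is compound 4 `C[C@@H]1C(C(=O)O)=C[C@@]2(C)CC[C@@H]3[C@@H](C)C[C@H](O)[C@@]132`, which has not yet been measured. Its difference from compound 2 is this: hydrogen in place of acetyl on an oxygen on a saturated carbon. Put simply, acetoxy becomes hydroxy.

Among the measured compounds shown here, no measured step covers this change. For the measured compounds named here, the only step available, a step that the two limits leave unreadable from compound 2 to compound 3, concerns another place in the molecule and gives no size to carry over. Compound 1 carries no acetoxy group and gives > 10 ug/mL, again a limit. This offers only a weak hint that losing the acetoxy group need not bring activity into the measurable range. No step beyond the usual scatter, in either direction, is therefore expected in this assay, and compound 4 will most likely report only a limit as well. The expected change is a step that the limit leaves unreadable from compound 2 to compound 4. For compound 4 the estimated value is 20 ug/mL, with an expected range from 8 ug/mL to 50 ug/mL.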

Compound 4, concentration for half-maximal effect: > 10 ug/mL
Compound 4: a limit, no number; the forecaster's own chance of this, stated with the estimate: 85%; the middle value lies beyond the limit too.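

In this assay compound 4 gives > 10 ug/mL, which is a limit and not a number. Compound 2 also sits at a limit, so no step can be read from compound 2 to compound 4, or between any others: the limit of > 10 ug/mL in this assay, at which 4 of the 4 values shown sit.

The compounds shown leave open how far apart these four truly lie, and whether changing acetoxy to hydroxy alters the effect at all.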